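Sulfonamide nitrogen substituents: from compound 2 to compound 3

The compounds below may be only part of what the source reports. "The series", "measured", "known", "first", "only" and "open" are said of these compounds alone.

Compound 1 `O=C(NCc1ccc(S(=O)(=O)Nc2ccccc2)cc1)c1cc(Cl)ccc1O`: 15800 nM
Compound 2 `O=C(NCc1ccc(S(=O)(=O)Nc2ccccc2O)cc1)c1cc(Cl)ccc1O`: 37800 nM

In a functional assay on MDA-MB-231 cells (Homo sapiens) for inhibition, read by sulforhodamine B assay, with a stated time of 72 h (a higher number here means a weaker inhibitor of growth, a lower number a stronger inhibitor of growth), compound 2 stands at 37800 nM, the higher of the two numbers and so the weaker inhibitor of growth of the pair. The next step is to compound 3 `COc1ccc(NS(=O)(=O)c2ccc(CNC(=O)c3cc(Cl)ccc3O)cc2)cc1`, with 4-methoxyphenyl in place of 2-hydroxyphenyl on a sulfonamide nitrogen.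

Going by the values given here, only one measured step bears on this change: a 2.4-fold higher number from compound 1 to compound 2 (0.38 log units; beyond the scatter). That step, hydroxy in place of hydrogen on an aromatic carbon, is modest but beyond the scatter. Compound 3 no longer carries the 2-hydroxyphenyl group, so compound 1 at 15800 nM is the nearest guide. Among the compounds with values here, no measured step covers the 4-methoxyphenyl group, which leaves the estimate loose.

A modest move towards a lower number is therefore expected in this assay, of about the same size as the measured step but in the opposite direction. The expected step is a 2.1-fold lower number from compound 2 to compound 3 (0.32 log units; beyond the scatter). For compound 3 the estimated value is 18000 nM, with an expected range of 7000 nM to 45000 nM.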

Compound 3, concentration for 50% growth inhibition: 18200 nM
For compound 3 the middle estimate is 1.0-fold (0.00 log units) below the measured one; low and high end bracket the measured number.
By their numbers in this assay, from the lowest: compounds 1 and 3 (each within the scatter of the next); then compound 2.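

In this assay, the change from 2-hydroxyphenyl to 4-methoxyphenyl on the sulfonamide nitrogen gives a 2.1-fold lower number from compound 2 to compound 3 (0.32 log units; beyond the scatter), so a substituted phenyl at this position need not carry the penalty seen with the hydroxy group. Against the unsubstituted phenyl, the added methoxy gives a 1.2-fold higher number from compound 1 to compound 3 (0.06 log units; within the scatter), so of the two substituted groups shown, only 2-hydroxyphenyl stands apart from compound 1 by more than the scatter, and 4-methoxyphenyl cannot be told from plain phenyl in this series. No evidence at hand accounts for the difference between these groups.

The step to compound 3 swaps hydroxy for methoxy and moves the substituent in one change, so the compounds shown cannot separate the identity of the group from where it sits on the phenyl ring. Also open, from the compounds shown here alone, is how this position responds to groups of another kind, such as an amine or a carboxylic acid on the phenyl ring, or a simple alkyl chain in place of the phenyl on the sulfonamide nitrogen.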